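Aryl amide replacing butanamide in the chromanone-ether series

The source may hold more compounds than are shown below. What is called first, only, known or untested is meant among the compounds shown, and "the series" means these compounds.

Measured compounds in an assay on isolated protein for inhibition of Rho-associated protein kinase 1 (Homo sapiens), read by scintillation counting, radiometric assay and 33P incorporation, with a stated time of 40 min, in the presence of a further agent that is not named here; on this read-out lower numbers stand for stronger inhibition and higher numbers for weaker inhibition:
- compound 1 `CN(C)c1ccc(C(=O)Nc2cccc(NC(=O)COc3ccc4c(c3)OCCC4=O)c2)cc1`: 144 nM
- compound 2 `Cc1coc2cc(OCC(=O)Nc3cccc(NC(=O)c4ccc(N(C)C)cc4)c3)ccc2c1=O`: > 10000 nM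
- compound 3 `CCCC(=O)Nc1cccc(NC(=O)COc2ccc3c(=O)ccoc3c2)c1`: 1430 nM

Compound 2 gives only a limit of the assay, (the limit of > 10000 nM in this assay, at which 1 of the 3 values shown sits), and no number. Of the two numbers shown, compound 3 stands highest; compound 1 sits clearly lower, beyond the usual scatter, with its 4-(dimethylamino)phenyl amide in place of the butanamide of compound 3. For the measured compounds named here, no two measured compounds differ in a single place, so no measured step is available.

Compound 4 `O=C(COc1ccc2c(=O)ccoc2c1)Nc1cccc(NC(=O)c2ccc(OC(F)(F)F)cc2)c1` is not yet measured. It differs from compound 3 in one place: 4-(trifluoromethoxy)phenyl in place of propyl on a carbonyl carbon. The change thus moves the series from an alkyl amide toward an aryl amide of the kind carried by compound 1, which gave 144 nM in this assay.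

For compound 4 a step from compound 3 toward lower numbers, beyond the scatter, is expected, a 4.1-fold lower number from compound 3 to compound 4 (0.61 log units; beyond the scatter), on the basis that compound 1 with its aryl amide reached 144 nM while compound 3 gave 1430 nM. The estimate for compound 4 is 350 nM, with a range from 90 nM to 1400 nM.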

Compound 4, half-maximal inhibitory concentration: 869 nM
Compound 4: the middle estimate sits 2.5-fold (0.39 log units) below what was measured; low and high end bracket the measured number.
By their numbers in this assay, from the lowest: compound 1; then compounds 4 and 3 (each within the scatter of the next). At a limit, above all of these: compound 2.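

In this assay the carbonyl carbon of this amide accepts a substantial exchange with little trace in the read-out: with 4-(trifluoromethoxy)phenyl in place of propyl, the measured step is a 1.6-fold lower number from compound 3 to compound 4 (0.22 log units; within the scatter). For the compounds shown here, this is the first reading of a single change, as the earlier compounds offered no pair differing in one place, and on the core shared by compound 3 and compound 4 the aryl amide does not separate from the butanamide. Nothing measured here speaks to the reason for this outcome.

On these data alone, compound 1 and compound 4 differ in more than one place, so it remains open whether the 4-(dimethylamino)phenyl amide of compound 1 would read differently from 4-(trifluoromethoxy)phenyl on the core of compound 4, or whether the core itself sets the level. Also open, as far as these compounds go, is how this core would respond to a carboxylic acid on the phenyl ring, or to a hexyl chain in place of propyl on the same carbonyl carbon.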